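Aryl in place of cyclohexyl on the amine nitrogen

The source may report more compounds than this note shows. Statements on the series, on what has been measured and on what is new or still open speak of the compounds shown alone.

Compound 1, `O=C1C(Nc2ccc(Br)cc2)=CC(=O)c2c1nc1n2[C@H]2OC[C@@H](O)[C@H]2OC1`: 4330 nM
Compound 2, `O=C1C=C(NC2CCCCC2)C(=O)c2c1nc1n2[C@H]2OC[C@@H](O)[C@H]2OC1`: > 8000 nM
Compound 3, `CCOc1ccccc1NC1=CC(=O)c2c(nc3n2[C@H]2OC[C@@H](O)[C@H]2OC3)C1=O`: > 4000 nM

In a functional assay on MCF7 cells (Homo sapiens) for inhibition, read by sulforhodamine B assay (a lower number here means a stronger inhibitor, a higher number a weaker inhibitor), compound 1 gives 4330 nM. For compound 2 the assay reports only a limit, > 8000 nM, namely (the limit of > 8000 nM in this assay, at which 1 of the 3 values shown sits). For compound 3 it likewise reports only a limit, > 4000 nM, namely (the limit of > 4000 nM in this assay, at which 1 of the 3 values shown sits). The step that the limit leaves unreadable from compound 1 to compound 3 is thus not readable. Compound 4, `O=C1C=C(Nc2cccc(Cl)c2)C(=O)c2c1nc1n2[C@H]2OC[C@@H](O)[C@H]2OC1`, is not yet measured; it differs from compound 2 by 3-chlorophenyl in place of cyclohexyl on an amine nitrogen. Among the measured compounds shown here, no measured step shares this change, and compound 2 itself stands only at a limit, so neither size nor direction can be read from the data. Compound 1 carries a 4-bromophenyl on the same nitrogen, and on that footing compound 4 is expected to give 4500 nM, within 1500 nM to 15000 nM. That estimate implies the step of an at least 1.7-fold lower number from compound 2 to compound 4 (0.24 log units; that floor lies within the scatter), taken from a limit.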

Compound 4, half-maximal inhibitory concentration: 4720 nM
Compound 4: the middle estimate sits 1.0-fold (0.02 log units) below what was measured, within the range that was stated.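

In this assay, 3-chlorophenyl in place of cyclohexyl on the amine nitrogen appears as an at least 1.6-fold lower number from compound 2 to compound 4 (0.22 log units; that floor lies within the scatter). Among the compounds shown here, this is the first step at this position that can be read at all, but it gives only a floor, so it does not establish that the aryl group outperforms cyclohexyl. That floor rests on a limit for compound 2: the limit of > 8000 nM in this assay, at which 1 of the 4 values shown sits.

Going by these compounds, how far cyclohexyl truly lies from 3-chlorophenyl remains open. So does what an unsubstituted phenyl or a benzyl on the same nitrogen would give.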